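The source may hold more compounds than are shown below. What is called first, only, known or untested is meant among the compounds shown, and "the series" means these compounds.

Compound 1 (`COc1cccc(CNC(=O)c2nc(Br)c3cccnc3c2N[C@H]2CC[C@H](N)CC2)c1`) gives 6000 nM
Compound 2 (`COc1ccc(CNC(=O)c2nc(Br)c3cccnc3c2N[C@H]2CC[C@H](N)CC2)cc1`) gives 3000 nM

Both numbers come from a functional assay on HCT-116 cells (Homo sapiens) for cytotoxicity, read by MTT assay, with a stated time of 72 h; on this read-out higher numbers stand for weaker inhibition and lower numbers for stronger inhibition. Within the data shown here, compound 2 stands at 3000 nM, and compound 1, the only other measured compound, lies within the usual scatter of it. The next compound to be tested is compound 3 (`N[C@H]1CC[C@H](Nc2c(C(=O)NCc3ccc(Cl)cc3Cl)nc(Br)c3cccnc23)CC1`), which carries 2,4-dichlorophenyl in place of 4-methoxyphenyl on a saturated chain carbon bound to an amide-type nitrogen. The counted difference reads: 2,4-dichlorophenyl in place of 4-methoxyphenyl on a saturated chain carbon bound to an amide-type nitrogen. Among the measured compounds shown here, only one measured step bears on this place, a 2.0-fold lower number from compound 1 to compound 2 (0.30 log units; within the scatter). For the measured compounds named here, that step stays within the scatter, and no measured compound carries chlorine, so the data give no direction for this swap. No step beyond the scatter is therefore expected in this assay. The expected change is a 1.2-fold lower number from compound 2 to compound 3 (0.08 log units; within the scatter). For compound 3 the estimate is 2500 nM, with an expected range from 700 nM to 8000 nM.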

Compound 3, half-maximal inhibitory concentration: 6000 nM
Beside the measured number, compound 3's estimate is 2.4-fold (0.38 log units) below it; low and high end bracket the measured number.
By their numbers in this assay, from the lowest: compounds 2, 1 and 3 (each within the scatter of the next).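

In this assay the step to 2,4-dichlorophenyl reads a 2.0-fold higher number from compound 2 to compound 3 (0.30 log units; within the scatter) and the second comparison reads no change at the digits printed from compound 1 to compound 3 (within the scatter) so neither step leaves the scatter. The place on a saturated chain carbon bound to an amide-type nitrogen has now held 3-methoxyphenyl, 4-methoxyphenyl and 2,4-dichlorophenyl, and the numbers do not separate these three groups. Swapping the oxygen-bearing methoxy group for two chlorine atoms thus gives no readable change in this cell test, and nothing measured here speaks to why the three numbers lie so close.

Still open, from the compounds shown here alone, is whether another group at this place, such as an unsubstituted phenyl, a pyridine ring or a phenyl carrying a carboxylic acid, would give a step beyond the scatter. A phenyl with a single chlorine and a longer chain in place of the saturated carbon are open as well.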